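Shortening one chain of compound 3

The source may report more compounds than this note shows. Statements on the series, on what has been measured and on what is new or still open speak of the compounds shown alone.

The series consists of acylguanidines carrying unsaturated chains on both acyl sides. Compound 1 `CC(C)=CCC/C(C)=C/C(=O)NC(=N)NC(=O)C=C(C)C`, compound 2 `CC(C)=CCC/C(C)=C/C(=O)NC(=N)NC(=O)/C=C(\C)CCC=C(C)C` and compound 3 `CC(C)=CCC/C(C)=C/CC/C(C)=C/C(=O)NC(=N)NC(=O)/C=C(\C)CC/C=C(\C)CCC=C(C)C` have been run in a functional assay on B16-F10 cells (Mus musculus) for inhibition, read by MTT assay, with a stated time of 72 h; a higher number here means a weaker inhibitor of growth, a lower number a stronger inhibitor of growth. Compound 1 gives 25000 nM, compound 2 gives 23800 nM and compound 3 gives 5700 nM, so compound 3 holds the lowest number of the three, beyond the scatter from both others. For the measured compounds named here, the only single-site step measured, a 1.1-fold lower number from compound 1 to compound 2 (0.02 log units; within the scatter), shows that adding that group on one chain left the number essentially where it was. Compound 4 `CC(C)=CCC/C(C)=C/CC/C(C)=C/C(=O)NC(=N)NC(=O)/C=C(\C)CCC=C(C)C` is obtained from compound 3 by hydrogen in place of 3-methylbut-2-en-1-yl on a saturated chain carbon bound to a double-bonded chain carbon. That is the same kind of change run backwards, so on the strength of the step from compound 1 to compound 2 alone no shift beyond the scatter would be expected. Against that, compound 2 and compound 3 differ in both chains and their values lie apart beyond the scatter, and compound 4 sits between them in chain length; which chain carries that gap cannot be told from the data. The expected outcome is therefore a modest rise, a 2.1-fold higher number from compound 3 to compound 4 (0.32 log units; beyond the scatter), with compound 4 estimated at 12000 nM (range 5000 nM to 28000 nM).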

Compound 4, concentration for 50% growth inhibition: 18900 nM
The estimate for compound 4 lay 1.6-fold (0.20 log units) below the measured number, and the stated range covers the measured number.
By their numbers in this assay, from the lowest: compound 3; then compounds 4, 2 and 1 (each within the scatter of the next).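

In this assay, the effect of 3-methylbut-2-en-1-yl on a saturated chain carbon bound to a double-bonded chain carbon is now seen to differ by core, since removing it gives a 3.3-fold higher number from compound 3 to compound 4 (0.52 log units; beyond the scatter). Compound 4 stays level with the compounds carrying shorter chains, with a 1.3-fold lower number from compound 2 to compound 4 (0.10 log units; within the scatter) and a 1.3-fold lower number from compound 1 to compound 4 (0.12 log units; within the scatter), so among the steps shown only the one involving compound 3 lies beyond the scatter. The same group therefore counts on one core and not on the other: the same change on two cores in this assay, a 1.1-fold lower number (0.02 log units; within the scatter) from compound 1 to compound 2 and a 3.3-fold lower number (0.52 log units; beyond the scatter) from compound 4 to compound 3, 3.2-fold (0.50 log units) apart, beyond the scatter of two such steps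

Going by these compounds, whether a longer chain on both sides would lower the number further remains open. Also open, on these data alone, is whether an amine or a carboxylic acid in place of 3-methylbut-2-en-1-yl would keep the number of compound 3.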